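Ethyl for Cyclopropyl on an Acyl Urea: Lipophilicity Outlook

The source may report more compounds than this note shows. Statements on the series, on what has been measured and on what is new or still open speak of the compounds shown alone.

Measured so far in a physicochemical assay for lipophilicity; on this read-out lower numbers stand for lower lipophilicity and higher numbers for higher lipophilicity:
compound 1 `CN1CCN(CCCS(=O)(=O)c2ccc3nc(NC(=O)NC(=O)c4cc(C5CC5)ccc4Cl)sc3c2)CC1` gives 2.9;
compound 2 `CN1CCN(CCCS(=O)(=O)c2ccc3nc(NC(=O)NC(=O)c4cc(N5CCCC5)c(C#N)cc4Cl)sc3c2)CC1` gives 2.8;
compound 3 `CN1CCC(S(=O)(=O)c2ccc3nc(NC(=O)NC(=O)c4cc(N5CCCC5)ccc4Cl)sc3c2)CC1` gives 3.1.

The three numbers sit close together. Compound 1 is separated from compound 2 and from compound 3 by gaps that both fall within the usual scatter, so no ordering among them can be claimed.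

Compound 4 `CCc1ccc(Cl)c(C(=O)NC(=O)Nc2nc3ccc(S(=O)(=O)CCCN4CCN(C)CC4)cc3s2)c1` has not yet been measured. It differs from compound 1 in one place: ethyl in place of cyclopropyl on an aromatic carbon. Nothing measured here tracks this change, so the expectation rests on the closeness of the existing values and the small size of the swap. Compound 4 is expected to show a step of a number 0.10 log units lower from compound 1 to compound 4 (within the scatter) that does not exceed the scatter. Compound 4 is therefore estimated at 2.8, with a range from 2.5 to 3.2.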

Compound 4, distribution coefficient: 2.9
For compound 4 the middle estimate is 0.10 log units below the measured one; measured number inside the range.
By their numbers in this assay, from the lowest: compounds 2, 1, 4 and 3 (each within the scatter of the next).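

In this assay, going by these compounds alone, ethyl in place of cyclopropyl on the aromatic carbon para to the chloro group gives no change at the digits printed from compound 1 to compound 4 (within the scatter) and provides the first step here that differs in only one place. Removing the three-membered ring and going from 3 heavy atoms to 2 thus leaves the read-out within the scatter for this pair. No measured evidence here accounts for this result.

Going by these compounds, whether a longer chain, an amine or a carboxylic acid on this aromatic carbon would read the same stays open. So does whether this swap behaves alike on a different core.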